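This account rests on a few compounds, and the source may have more. Where it says the series, first, only, none or still open, it means among the compounds named here.

Measured compounds:
compound 1 `Cc1cccc(-c2ccc(N(C[C@@H](N)CC(C)C)C(=O)[C@@H]3C[C@H]3c3ccccc3)cc2)c1` with 1200 nM
compound 2 `CC(C)C[C@H](N)CN(C(=O)[C@@H]1C[C@H]1c1ccccc1)c1ccc(-c2cccc(F)c2)cc1` with 2100 nM

In a functional assay for agonist activity at G protein-coupled receptor 88 (Homo sapiens), read by HTRF and cAMP accumulation (a lower number here means that less compound is needed, a higher number that more compound is needed for the effect), compound 2 gives the higher of the two numbers, but the step between them is a 1.8-fold higher number from compound 1 to compound 2 (0.24 log units; within the scatter), which is within the scatter, so the two cannot be told apart. Compound 3 `CC(C)C[C@H](N)CN(C(=O)[C@@H]1C[C@H]1c1ccccc1)c1ccc(-c2ccc(C#N)cc2)cc1` is not yet measured. It differs from compound 2 in one place: 4-cyanophenyl in place of 3-fluorophenyl on an aromatic carbon. Among the measured compounds shown here, the only measured step that bears on this is the one from compound 1 to compound 2, where a fluoro replaced a methyl on the same aromatic ring and the number moved by a 1.8-fold higher number from compound 1 to compound 2 (0.24 log units; within the scatter), within the scatter. The new change is larger, adding a nitrile and moving the substituent to another position, so the outcome is less certain. Compound 3 is expected to give 2500 nM in this assay, in the range 800 nM to 8000 nM, which means an expected step of a 1.2-fold higher number from compound 2 to compound 3 (0.08 log units; within the scatter) from compound 2.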

Compound 3, half-maximal effective concentration: 670 nM
For compound 3 the middle estimate is 3.7-fold (0.57 log units) above the measured one; measured number below the stated range.
By their numbers in this assay, from the lowest: compounds 3, 1 and 2 (each within the scatter of the next, the first and the last beyond it).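

In this assay, among the compounds shown here, this is the first swap of the aromatic group that gives a step beyond the scatter: 4-cyanophenyl in place of 3-fluorophenyl gives a 3.1-fold lower number from compound 2 to compound 3 (0.50 log units; beyond the scatter). Set against the 3-methylphenyl group, the same 4-cyanophenyl group gives a 1.8-fold lower number from compound 1 to compound 3 (0.25 log units; within the scatter), so compound 3 cannot be told apart from compound 1 and stands clear only of compound 2. Nothing available explains the difference between these groups.

This change replaces the group and moves the substituent at once, so the compounds shown cannot separate the effect of the nitrile from that of its position. From the compounds shown here alone, a 3-cyanophenyl or 4-fluorophenyl group would help to separate them, and how an amine or a carboxylic acid on that ring would read remains open.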